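Swapping a Trimethoxyphenyl for a Trifluoromethylphenyl

A few compounds are considered here, and "the series" means these few. Any claim that something is new, unique, unknown or untested is made for them only; others in the source may bear on it.

Three measured compounds are compared in an ADME assay on Vero cells (Chlorocebus sabaeus) for cytotoxicity, read by MTT assay, with a stated time of 72 h; on this read-out lower numbers stand for higher toxicity in this test and higher numbers for lower toxicity in this test. Compound 1 `COC(=O)c1cc(-c2cccc(NC(=O)c3ccc(OCc4ccc(Cl)cc4)cc3)c2)on1` reaches only a limit of the test, > 80 ug/mL. Compound 3 `CC(C)Cc1ccc(C(=O)/C=C/c2ccc(C(=O)O)cc2)cc1` also stops at a limit, < 10 ug/mL. Compound 2 `COC(=O)c1cc(-c2cccc(NC(=O)c3ccc(/C=C/C(=O)c4cc(OC)c(OC)c(OC)c4)cc3)c2)on1` likewise gives only a limit, > 50 ug/mL, so where it stands on the numbers is the limit of > 50 ug/mL in this assay, at which 1 of the 3 values shown sits, a limit rather than a measured number. Compound 4 `COC(=O)c1cc(-c2cccc(NC(=O)c3ccc(/C=C/C(=O)c4cccc(C(F)(F)F)c4)cc3)c2)on1` is not yet measured; it differs from compound 2 by 3-(trifluoromethyl)phenyl in place of 3,4,5-trimethoxyphenyl on a carbonyl carbon. Within the data shown here, no measured step between compounds shows what this change does, so the expected step of a number no higher from compound 2 to compound 4 (the limit leaves the size open) is none beyond the scatter. Compound 4 is expected to give 50 ug/mL, within 20 ug/mL to 100 ug/mL, in this assay.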

Compound 4, half-maximal cytotoxic concentration: > 20 ug/mL
Compound 4 was reported as a limit (the forecaster's own chance of this, stated with the estimate: 55%); the middle value is on the limit's open side.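

Among these compounds, compound 2 and compound 4 both give only limits of the test, and no step between them can be read. On these data alone, what 3-(trifluoromethyl)phenyl in place of 3,4,5-trimethoxyphenyl does in this assay remains open.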